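The compounds below may be only part of what the source reports. "The series", "measured", "known", "first", "only" and "open" are said of these compounds alone.

Compound 1 `CC(C)=CCC1Cc2c(OCc3ccccc3)cc(=O)n(CCCO)c2CC1(C)C`, compound 2 `CC(C)=CCC1Cc2c(OC(=O)Nc3ccc(Cl)c(Cl)c3)cc(=O)n(CCCO)c2CC1(C)C` and compound 3 `CC(C)=CCC/C(C)=C/CC1Cc2c(OCc3ccccc3)cc(=O)n(CCCO)c2CC1(C)C` share one core and were all tested in a functional assay on PANC-1 cells (Homo sapiens) for inhibition, read by MTT assay, with a stated time of 24 h, tested at 10 uM; a lower number here means less inhibition, a higher number more inhibition at the concentration tested (going by the name of the read-out). Compound 1 gives -0.3%, compound 2 gives 61.4%, and compound 3 gives 46.5%. Compound 3 thus stands second of the three: compound 2 lies above it, and compound 1 lies well below it, both gaps beyond the scatter.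

Compound 4 `CC(C)=CCC/C(C)=C/CC1Cc2c(OC(=O)Nc3ccc(F)c(F)c3)cc(=O)n(CCCO)c2CC1(C)C` differs from compound 3 in one place: (3,4-difluorophenyl)carbamoyl in place of benzyl on an oxygen on an aromatic ring. Going by the values given here, the closest measured step is the one from compound 1 to compound 2, where a dichlorophenylcarbamoyl group replaced benzyl on the same oxygen and gave a number 61.7 percentage points higher from compound 1 to compound 2 (beyond the scatter). Compound 4 carries fluorine where compound 2 carries chlorine, so the effect need not be equal, and compound 3 already starts from a higher level, which leaves less room upward. A clear rise in this assay is therefore expected, though likely smaller than that earlier step.

Compound 4 is expected to give 75%, within 50% to 95%. This would be an expected step of a number 28.5 percentage points higher from compound 3 to compound 4 (beyond the scatter) in this assay.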

Compound 4, a percentage reported as inhibition, at one concentration (the size of the read-out at that concentration, not a potency): 43.7%
For compound 4 the middle estimate is 31.3 percentage points above the measured one, and the stated range ends above it.
By their numbers in this assay, from the lowest: compound 1; then compounds 4 and 3 (each within the scatter of the next); then compound 2.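

With the longer chain of compound 3 in place, putting (3,4-difluorophenyl)carbamoyl in place of benzyl on this oxygen gives a number 2.8 percentage points lower from compound 3 to compound 4 (within the scatter) in this assay, so a carbamoyl group at this position does not bring a rise in every setting. The earlier exchange, with the dichlorinated group on the shorter chain, gave a number 61.7 percentage points higher from compound 1 to compound 2 (beyond the scatter) and had suggested otherwise. At this position, benzyl and the difluorinated carbamoyl cannot be told apart on this chain, and nothing measured here explains that result.

The compounds shown leave open whether the difference between the two exchanges follows the fluorine atoms or the chain, which (3,4-dichlorophenyl)carbamoyl on the chain of compound 3 could separate. They also leave open how an unsubstituted phenylcarbamoyl group or an amine-bearing group would read on this oxygen.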